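Aryl thioureas: ring substitution and inhibition

The source may hold more compounds than are shown below. What is called first, only, known or untested is meant among the compounds shown, and "the series" means these compounds.

Measured so far:
compound 1, `CCc1ccc(NC(N)=S)cc1`: 88%
compound 2, `CC(C)(C)c1ccccc1NC(N)=S`: < 10%

In a functional assay on B16 cells (Mus musculus) for inhibition, tested at 10 uM (a higher number here means more inhibition at the concentration tested (going by the name of the read-out), a lower number less inhibition), compound 1, `CCc1ccc(NC(N)=S)cc1`, gives 88%. For compound 2, `CC(C)(C)c1ccccc1NC(N)=S`, the read-out in this assay is a limit of the assay rather than a number, < 10%. Among the measured compounds shown here, compound 2 thus sits at the floor of what has been recorded (the limit of < 10% in this assay, at which 1 of the 2 values shown sits), and no step between two measured compounds is available to size the effect of any change.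

The next compound, compound 3, `NC(=S)Nc1ccccc1CO`, is reached from compound 2 by one change: hydroxymethyl in place of tert-butyl on an aromatic carbon, on an aromatic carbon of a six-membered aromatic ring of carbon only, ortho to a group of 4 heavy atoms. Since compound 2 is at a limit, any move can only be upward or none. For the measured compounds named here, with no measured step to lean on, the expectation for compound 3 in this assay is a step of a number at least 15 percentage points higher from compound 2 to compound 3 (beyond the scatter), upward but modest, and quite possibly still within the scatter of the limit. Compound 3 is estimated at 25%, with a range from 5% to 60%.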

Compound 3, a percentage reported as inhibition, at one concentration (the size of the read-out at that concentration, not a potency): < 10%
Compound 3 gave a limit, no number; the forecaster's own chance of this, stated with the estimate: 35%; at least 15 percentage points between middle value and limit.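

In this assay, among the compounds shown here, compound 2 and compound 3 both give a limit of the assay rather than a number, so no step between them can be read and the change from tert-butyl to hydroxymethyl cannot be sized: the limit of < 10% in this assay, at which 2 of the 3 values shown sit. The compounds shown leave open whether any group on that aromatic carbon gives a readable inhibition value.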